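Trimming the Carboxy Side Chain in a Diaryl Ether Urea Series

The source may hold more compounds than are shown below. What is called first, only, known or untested is meant among the compounds shown, and "the series" means these compounds.

Going by the values given here, in a functional assay on CHO cells for antagonist activity at sphingosine 1-phosphate receptor 2 (Homo sapiens), read by fluorescence (on this read-out higher numbers stand for weaker inhibition and lower numbers for stronger inhibition), compound 1 `CC(C)CC1(O)CCN(C(=O)Nc2cc(Oc3ccc(F)cc3)cc(Oc3ccc(C4(C(=O)O)CC4)cc3)c2)CC1` gives 6.4 nM and stands second highest of the three numbers measured so far. Its nearest neighbour is compound 2 `CC(C)CC1(O)CN(C(=O)Nc2cc(Oc3ccc(F)cc3)cc(Oc3ccc(C(C)(C)C(=O)O)cc3)c2)C1`, which gives 5.2 nM in this assay, a value within the usual scatter of that of compound 1. The furthest is compound 3 `CC(C)CC1(O)CCN(C(=O)Nc2cc(Oc3ccc(F)cc3)cc(Oc3ccc(C(=O)O)cc3F)c2)CC1`, which gives 17 nM; the step of a 2.7-fold higher number from compound 1 to compound 3 (0.42 log units; beyond the scatter) is modest but lies beyond the scatter.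

Compound 4 `CC(C)CC1(O)CCN(C(=O)Nc2cc(Oc3ccc(F)cc3)cc(Oc3ccc(CC(=O)O)cc3)c2)CC1` differs from compound 1 in one place: carboxymethyl in place of 1-carboxycyclopropyl on an aromatic carbon. Among the compounds with values here, of the measured steps, only that from compound 1 to compound 3 bears on this change, since it too replaces the 4-(1-carboxycyclopropyl)phenyl group, and it raised the number modestly. Compound 2 carries a different carboxy-bearing group on a different core and offers no single-point comparison. A small shift toward a higher number is therefore expected for compound 4, a 1.6-fold higher number from compound 1 to compound 4 (0.19 log units; within the scatter), giving an estimated 10 nM with a range of 4 nM to 25 nM.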

Compound 4, half-maximal inhibitory concentration: 21 nM
For compound 4 the middle estimate is 2.1-fold (0.32 log units) below the measured one; the measured number falls inside the stated range.
By their numbers in this assay, from the lowest: compounds 2 and 1 (each within the scatter of the next); then compounds 3 and 4 (each within the scatter of the next).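

Replacing 1-carboxycyclopropyl with carboxymethyl on this aromatic carbon gives a modest loss (a 3.3-fold higher number from compound 1 to compound 4 (0.52 log units; beyond the scatter)) in this assay, so on the core of compound 1 the open carboxymethyl group does not match the ring-bearing group. The two replacements of 4-(1-carboxycyclopropyl)phenyl now shown cannot be told apart (a 1.2-fold higher number from compound 3 to compound 4 (0.09 log units; within the scatter)), and both stand on the higher side of compound 1. Nothing available explains the loss.

It remains open how the 1-carboxy-1-methylethyl group of compound 2, shown only on a different core, would read on the core of compound 1. Also open, as far as these compounds go, is whether a longer chain such as 2-carboxyethyl, or a larger ring such as 1-carboxycyclobutyl, would hold the number at this position.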